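A few compounds are considered here, and "the series" means these few. Any claim that something is new, unique, unknown or untested is made for them only; others in the source may bear on it.

Measured compounds:
compound 1 `COc1ccc(-c2cnc3nc(N)nc(N4CCN(c5ccc(F)cc5)CC4)c3n2)cc1OC` — 100 nM
compound 2 `COc1ccc(-c2cnc3nc(N)nc(N4CCN(C(=O)Nc5cccc(C)c5)CC4)c3n2)cc1OC` — 7 nM

Both were tested in a functional assay on cells (T-cell, Homo sapiens) for inhibition; on this read-out higher numbers stand for weaker inhibition and lower numbers for stronger inhibition; compound 1 gives 100 nM there, and compound 2 gives 7 nM. For the measured compounds named here, compound 2 therefore holds the lowest of the two numbers, and the only step available, a 14-fold lower number from compound 1 to compound 2 (1.15 log units; beyond the scatter), comes from exchanging the group on the amine nitrogen of the ring, where the (3-methylphenyl)carbamoyl arm brought a large gain over the 4-fluorophenyl arm.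

Compound 3 `COc1ccc(-c2cnc3nc(N)nc(N4CCN(C(=O)COc5ccc(Cl)cc5)CC4)c3n2)cc1OC` is not yet measured. It differs from compound 2 at the carbonyl carbon: (4-chlorophenoxy)methyl in place of (3-methylphenyl)amino on a carbonyl carbon. The carbonyl and the ring nitrogen it sits on are kept, but the (3-methylphenyl)amino, with its single hydrogen-bond donor, gives way to (4-chlorophenoxy)methyl, which carries one hydrogen-bond acceptor and no donor. Going by the values given here, the one measured step bears on this only indirectly, since it shows that this position tolerates sizeable changes with large effect, in either direction. Among the compounds with values here, a modest loss is expected, a 2.9-fold higher number from compound 2 to compound 3 (0.46 log units; beyond the scatter), because compound 2 already sits at 7 nM and no measured step shows what removing the donor does. Compound 3 is therefore estimated at 20 nM, within 5 nM to 80 nM.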

Compound 3, half-maximal inhibitory concentration: 0.5 nM
The estimate for compound 3 lay 40-fold (1.60 log units) above the measured number; measured number below the stated range.
By their numbers in this assay, from the lowest: compound 3; then compound 2; then compound 1.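

In this assay, placing (4-chlorophenoxy)methyl on the carbonyl carbon in place of (3-methylphenyl)amino gave a 14-fold lower number from compound 2 to compound 3 (1.15 log units; beyond the scatter), so in this pair a hydrogen-bond donor on the arm was not required for a low number, and the arm with no donor and one hydrogen-bond acceptor gave the lowest number of the three compounds. Against the 4-fluorophenyl arm on the ring nitrogen, the ((4-chlorophenoxy)methyl)carbonyl arm gave a 200-fold lower number from compound 1 to compound 3 (2.30 log units; beyond the scatter), so both arms that keep a carbonyl on that nitrogen now stand well below compound 1, and the gain is not confined to the (3-methylphenyl)carbamoyl arm. Nothing shown here accounts for the size of these steps.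

The change replaced the amino nitrogen with a methylene and ether oxygen and also replaced the methyl on the aromatic ring with a chlorine, and the compounds shown do not separate these parts. Going by these compounds, it remains open whether a (4-chlorophenyl)amino arm or a phenoxymethyl arm without the chlorine would hold the number of compound 3, and whether a longer chain in place of the methylene would do so.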